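The source may report more compounds than this note shows. Statements on the series, on what has been measured and on what is new or still open speak of the compounds shown alone.

Of the compounds shown here, two have numbers so far in a functional assay on the whole organism with Canis familiaris (Canis lupus familiaris) as the target; on this read-out lower numbers stand for an effect already at smaller amounts and higher numbers for an effect only at larger amounts of compound. Compound 1 (`CCNc1nc(C)nc(O)c1C#N`) gives 0.06 mg/kg, the higher of the two, and compound 2 (`Cc1nc(O)c(Br)c(NCc2cccnc2)n1`) gives 0.022 mg/kg, a gap beyond the usual scatter. Compound 3 (`CCNc1nc(C)nc(O)c1Br`) has not yet been measured in this assay. It differs from compound 1 by bromo in place of cyano on an aromatic carbon. The site is ortho to a hydroxy group and ortho to an ethylamino group. Going by the values given here, no measured pair isolates this exchange, so the evidence for its size is thin. Compound 2 also carries bromo and gives 0.022 mg/kg, so a modest move toward a lower number is expected, though a step within the scatter remains possible. The expected change is a 1.7-fold lower number from compound 1 to compound 3 (0.23 log units; within the scatter). Compound 3 is estimated at 0.035 mg/kg, with an expected range from 0.012 mg/kg to 0.1 mg/kg.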

Compound 3, dose for half-maximal effect: 0.03 mg/kg
Estimate against measurement, compound 3: 1.2-fold (0.07 log units) above, and the stated range covers the measured number.
By their numbers in this assay, from the lowest: compounds 2, 3 and 1 (each within the scatter of the next, the first and the last beyond it).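

In this assay the exchange of cyano for bromo on the aromatic carbon ortho to a hydroxy group and ortho to an ethylamino group now has a direct reading, a 2.0-fold lower number from compound 1 to compound 3 (0.30 log units; within the scatter), with the rest of the core of compound 1 unchanged. With the ethylamino group held constant, this position therefore takes either group without a step beyond the scatter, although bromo has one heavy atom and no hydrogen-bond acceptor where cyano has two heavy atoms and one acceptor. Nothing measured here bears on why the two groups read alike.

The compounds shown leave open what chloro, methyl or a carboxylic acid would give on this carbon. Also open, going by these compounds, is whether the exchange reads the same with a longer chain in place of the ethylamino group.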